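A further chloro on compound 3

The compounds below may be only part of what the source reports. "The series", "measured", "known", "first", "only" and "open" are said of these compounds alone.

Measured in an ADME assay on J774 cells (Mus musculus) for cytotoxicity, read by resazurin assay, with a stated time of 72 h (a higher number here means that more compound is tolerated, a lower number that less compound is tolerated), so far:
- compound 1 `C/C(=N\Nc1nc(-c2ccccc2)cs1)c1ccc(Cl)c(Cl)c1` gives > 50000 nM
- compound 2 `C/C(=N\Nc1nc(-c2ccncc2)cs1)c1ccc(Cl)c(Cl)c1` gives 39800 nM
- compound 3 `C/C(=N\Nc1nc(-c2ccc(Cl)cc2)cs1)c1ccc(Cl)c(Cl)c1` gives > 50000 nM

Compound 3 gives > 50000 nM here, which is a limit and not a number. Compound 1 gives > 50000 nM as well, and that too is a limit.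

Compound 4 `C/C(=N\Nc1nc(-c2ccc(Cl)c(Cl)c2)cs1)c1ccc(Cl)c(Cl)c1` carries one change, (chloro in place of hydrogen on an aromatic carbon), which turns 4-chlorophenyl into 3,4-dichlorophenyl. The same kind of change, chloro in place of hydrogen on an aromatic carbon, appears in a step that the two limits leave unreadable from compound 1 to compound 3 and offers no size to work with. The pyridin-4-yl swaps, an at least 1.2-fold lower number from compound 1 to compound 2 (0.09 log units; that floor lies within the scatter) and an at least 1.2-fold higher number from compound 2 to compound 3 (0.09 log units; that floor lies within the scatter), reach only floors within the scatter. Because of the limit of > 50000 nM in this assay, at which 2 of the 3 values shown sit, these steps give no size to carry over, so no step beyond the scatter is expected in this assay and compound 4 may well report only a limit too.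

Compound 4 is estimated at 50000 nM, with an expected range of 22000 nM to 100000 nM in this reading. This estimate means a number no higher from compound 3 to compound 4 (the limit leaves the size open) and nothing beyond the scatter is expected.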

Compound 4, half-maximal cytotoxic concentration: > 50000 nM
Compound 4 ended at the assay's limit (the forecaster's own chance of this, stated with the estimate: 70%); the middle value sits exactly at the limit.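

Compound 4 gives > 50000 nM in this assay and that is a limit, so a second chloro on this ring, ortho to the chloro group already there, still yields no number. Going by these compounds alone, only one step to compound 4 can be read, and it is an at least 1.2-fold higher number from compound 2 to compound 4 (0.09 log units; that floor lies within the scatter) and no more. The steps to compound 4 from compound 1 and compound 3 cannot be read, because both ends of each are limits: the limit of > 50000 nM in this assay, at which 3 of the 4 values shown sit.

As far as these compounds go, how far compound 1, compound 3 and compound 4 lie past that limit stays open, so the size of the chloro change remains unknown. Also open, from the compounds shown here alone, is whether an amine or a carboxylic acid in place of this chloro would give a measurable number rather than another limit.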